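The source may hold more compounds than are shown below. What is called first, only, known or untested is meant among the compounds shown, and "the series" means these compounds.

Of the compounds shown here, two built on a shared core have been measured. Compound 1 `CCCC(=O)C1=Cc2ccc(OC)cc2OC1c1cc(OC)c(OC)c(OC)c1` gives 11700 nM in a functional assay for inhibition of nuclear factor NF-kappa-B complex (Homo sapiens); a higher number here means a weaker inhibitor, a lower number a stronger inhibitor. Compound 2 `COc1ccc2c(c1)OC(c1cc(OC)c(OC)c(OC)c1)C(C(=O)NC(C)C)=C2` reaches only a limit of the assay, > 50000 nM, in this assay. For the measured compounds named here, the single step measured, an at least 4.2-fold higher number from compound 1 to compound 2 (0.63 log units; beyond the scatter), is bounded by the limit of > 50000 nM in this assay, at which 1 of the 2 values shown sits, and so is known only as a floor. Compound 3 `COc1ccc2c(c1)OC(c1cc(OC)c(OC)c(OC)c1)C(C(=O)OC(C)(C)C)=C2` differs from compound 2 by tert-butoxy in place of isopropylamino on a carbonyl carbon. Going by the values given here, no measured step covers this exchange; the only one known, an at least 4.2-fold higher number from compound 1 to compound 2 (0.63 log units; beyond the scatter), concerns a different substituent at the same carbonyl carbon and gives no direction for the present change. Compound 2 stands at the weak end of the numbers shown. Compound 3 is therefore expected to move by an at least 1.2-fold lower number from compound 2 to compound 3 (0.09 log units; that floor lies within the scatter), a change not clearly beyond the scatter in this assay. The estimate for compound 3 in this assay is 40000 nM, in the range 12000 nM to 150000 nM.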

Compound 3, half-maximal inhibitory concentration: 14100 nM
Compound 3: middle estimate off by 2.8-fold (0.45 log units), on the high side; measured number inside the range.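

For the compounds shown here, putting tert-butoxy in place of isopropylamino on the carbonyl carbon gives an at least 3.5-fold lower number from compound 2 to compound 3 (0.54 log units; beyond the scatter) in this assay, so this exchange, which had no measured precedent, does change the reading. The size of that step is known only as a floor, as the value of compound 2 is a limit of the assay: the limit of > 50000 nM in this assay, at which 1 of the 3 values shown sits.

Propyl and tert-butoxy on this carbonyl carbon cannot be told apart in this assay, with a 1.2-fold higher number from compound 1 to compound 3 (0.08 log units; within the scatter), which leaves isopropylamino as the only one of the three groups that stands apart.

As far as these compounds go, the true value of compound 2 remains unknown, and with it the full size of the step. Also open, from the compounds shown here alone, is whether a dimethylamino group, a methoxy group or a carboxylic acid on this carbonyl carbon would read like isopropylamino or like tert-butoxy.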